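Furan in Place of Iodine on a Nucleoside Core

A few compounds are considered here, and "the series" means these few. Any claim that something is new, unique, unknown or untested is made for them only; others in the source may bear on it.

Compound 1 `COc1ncnc2c1c(-c1cccs1)cn2[C@@H]1O[C@H](CO)[C@@H](O)[C@H]1O`: 70 nM
Compound 2 `CN(C)c1ncnc2c1c(-c1cc3ccccc3o1)cn2[C@@H]1O[C@H](CO)[C@@H](O)[C@H]1O`: > 20000 nM
Compound 3 `Cc1nc(N)c2c(I)cn([C@@H]3O[C@H](CO)[C@@H](O)[C@H]3O)c2n1`: 5120 nM

In a functional assay on K562 cells (Homo sapiens), read by MTT assay, with a stated time of 72 h (a higher number here means a weaker inhibitor, a lower number a stronger inhibitor), compound 1 gives 70 nM. Compound 2 reaches only the limit of this assay, > 20000 nM, so no number is known for it. Compound 3 gives 5120 nM in this assay, the higher of the two numbers, and its gap to compound 1 lies well beyond the scatter. The value of compound 2 is a limit, as noted (the limit of > 20000 nM in this assay, at which 1 of the 3 values shown sits).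

Compound 4 `Cc1nc(N)c2c(-c3ccco3)cn([C@@H]3O[C@H](CO)[C@@H](O)[C@H]3O)c2n1` is not yet measured. It differs from compound 3 in one place: furan-2-yl in place of iodo on an aromatic carbon. Within the data shown here, no measured pair isolates this change, so what follows is an expectation only. Compound 1 carries a five-membered aromatic ring at the same place and gives 70 nM, which suggests that an aromatic ring there is compatible with a low number. Compound 4 is therefore expected to give a lower number than compound 3, the estimated step being an 8.5-fold lower number from compound 3 to compound 4 (0.93 log units; beyond the scatter). Compound 4 is estimated at 600 nM, within 100 nM to 3500 nM.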

Compound 4, half-maximal inhibitory concentration: > 20000 nM
Compound 4 gave a limit, no number; the forecaster's own chance of this, stated with the estimate: 5%; at least 33-fold (1.52 log units) between middle value and limit.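

On the core of compound 3, in this assay, furan-2-yl in place of iodo gives an at least 3.9-fold higher number from compound 3 to compound 4 (0.59 log units; beyond the scatter), so a five-membered aromatic ring at this aromatic carbon does not lower the number on this core, but raises it. The value of compound 4, > 20000 nM, is a limit of the assay and not a number, so the step gives only a minimum size. Compound 4 does not stand alone at this limit: the limit of > 20000 nM in this assay, at which 2 of the 4 values shown sit.

The compounds shown leave open how a smaller group at this place, such as a methyl or an aminomethyl, would compare with iodo on the same core. They also leave open whether furan-2-yl would fare any better on the core of compound 1.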